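Three measured analogues and one estimate for compound 4

The compounds below may be only part of what the source reports. "The series", "measured", "known", "first", "only" and "open" are said of these compounds alone.

Compound 1 `N#Cc1c(-c2ccccc2)c(C#N)c(=O)n(/N=C/c2cn(-c3ccccc3)nc2-c2ccccc2)c1N` gives 180 ug/mL in an ADME assay on NIH3T3 cells (Mus musculus) for cytotoxicity, read by MTT assay; a lower number here means a stronger inhibitor, a higher number a weaker inhibitor.
Compound 2 `N#Cc1c(-c2cccc(F)c2)c(C#N)c(=O)n(/N=C/c2cn(-c3ccccc3)nc2-c2ccccc2)c1N` gives 154 ug/mL in this assay.
Compound 3 `N#Cc1c(-c2cccc([N+](=O)[O-])c2)c(C#N)c(=O)n(/N=C/c2cn(-c3ccccc3)nc2-c2ccccc2)c1N` gives 124 ug/mL in this assay.

The three compounds share one core and differ only in the substituent on the pendant phenyl ring. The steps among them are small: a 1.2-fold lower number from compound 1 to compound 2 (0.07 log units; within the scatter), a 1.5-fold lower number from compound 1 to compound 3 (0.16 log units; within the scatter) and a 1.2-fold lower number from compound 2 to compound 3 (0.09 log units; within the scatter), each within the scatter, so compound 3 stands at one end of a narrow cluster rather than apart from it.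

Compound 4 `N#Cc1c(-c2ccccc2Br)c(C#N)c(=O)n(/N=C/c2cn(-c3ccccc3)nc2-c2ccccc2)c1N` continues from compound 3 by the change (2-bromophenyl in place of 3-nitrophenyl on an aromatic carbon). Going by the values given here, none of the measured steps involves a 2-bromophenyl group, so no step bears on it directly; the steps that do bear on substitution of this phenyl ring all stayed within the scatter. Compound 4 is therefore expected to show no step beyond the scatter in this assay, with a 1.2-fold higher number from compound 3 to compound 4 (0.08 log units; within the scatter) as the estimated change. For compound 4 the estimate in this assay is 150 ug/mL, with a range from 85 ug/mL to 260 ug/mL.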

Compound 4, half-maximal inhibitory concentration: 174 ug/mL
Estimate against measurement, compound 4: 1.2-fold (0.06 log units) below; the measured number falls inside the stated range.
By their numbers in this assay, from the lowest: compounds 3, 2, 4 and 1 (each within the scatter of the next).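

In this assay the 2-bromophenyl group of compound 4 gives a 1.4-fold higher number from compound 3 to compound 4 (0.15 log units; within the scatter) and a 1.1-fold higher number from compound 2 to compound 4 (0.05 log units; within the scatter) and also a 1.0-fold lower number from compound 1 to compound 4 (0.01 log units; within the scatter) with every step within the scatter. Until now only the 3-fluorophenyl and 3-nitrophenyl groups had been compared with the unsubstituted phenyl group at this place opposite the ring nitrogen, and the flat picture now extends to a bromo substituent and to a different ring position in these four compounds. The data offer no explanation for this flatness.

The compounds shown leave open whether an amine, a carboxylic acid or a longer chain on this phenyl ring would also stay within the scatter. Going by these compounds alone, they also leave open whether the ring position matters in its own right, since no pair carries the same substituent at two ring positions.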